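Fluoro in place of hydroxy: what to expect

This account rests on a few compounds, and the source may have more. Where it says the series, first, only, none or still open, it means among the compounds named here.

Compound 1 `COC1=C(C)C(=O)/C(=C(O)/C=C/c2ccc(Br)cc2)C(=O)C1(C)C` gives 1.4 ug/mL in a functional assay on A549 cells (Homo sapiens) for cytotoxicity; a lower number here means that less compound is needed, a higher number that more compound is needed for the effect
Compound 2 `COC1=C(C)C(=O)/C(=C(O)/C=C/c2ccc(O)cc2)C(=O)C1(C)C` gives 3.1 ug/mL in this assay

Of these two measured compounds, compound 2 has the higher number, so more of it is needed for the effect. The next compound is compound 3 `COC1=C(C)C(=O)/C(=C(O)/C=C/c2ccc(F)cc2)C(=O)C1(C)C`, which keeps the shared core but has fluoro in place of hydroxy on an aromatic carbon, para to a large group (fluoro in place of hydroxy on an aromatic carbon). Among the measured compounds shown here, one measured step bears on this change: a 2.2-fold higher number from compound 1 to compound 2 (0.35 log units; beyond the scatter), with hydroxy in place of bromo on an aromatic carbon. That step is modest, and fluoro is not bromo, so it offers only a rough guide. Removing the hydroxy might undo part of that step, so a small move toward a lower number is expected in this assay, possibly one that stays within the scatter. The expected size is a 1.6-fold lower number from compound 2 to compound 3 (0.19 log units; within the scatter), an estimate resting on a single step. For compound 3 the estimated value is 2 ug/mL, with an expected range from 0.9 ug/mL to 4.5 ug/mL.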

Compound 3, concentration for half-maximal effect: 3.3 ug/mL
Beside the measured number, compound 3's estimate is 1.7-fold (0.22 log units) below it; measured number inside the range.
By their numbers in this assay, from the lowest: compound 1; then compounds 2 and 3 (each within the scatter of the next).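

On the aromatic ring, para to a large group, replacing hydroxy with fluoro gives a 1.1-fold higher number from compound 2 to compound 3 (0.03 log units; within the scatter) in this assay, so a group that counts as a hydrogen-bond donor and acceptor and one that counts as neither cannot be told apart by this read-out. Among the compounds shown here, with this third compound, bromo is the only one of the three groups that separates from the others: a 2.4-fold higher number from compound 1 to compound 3 (0.37 log units; beyond the scatter) joins the earlier 2.2-fold higher number from compound 1 to compound 2 (0.35 log units; beyond the scatter) as a modest step beyond the scatter, and compound 1 has the lowest number of the three. No measurement offered here explains why bromo separates from fluoro and hydroxy while those two do not separate from each other.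

Three groups at one place on the ring are too few to show whether bromo is a lone case or part of a wider trend, and chloro, methyl, an amine or a carboxylic acid at this same place would test that further. It also remains open whether the same small differences among these groups would hold after a change elsewhere on the shared core.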